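A Second Fluorine on the Aryl Ring

This account rests on a few compounds, and the source may have more. Where it says the series, first, only, none or still open, it means among the compounds named here.

Compound 3 `COc1cc2c(Oc3ccc(NC(=O)c4nnn(-c5ccc(F)cc5)c4C(F)(F)F)cc3F)ccnc2cc1OCCCN1CCCCC1` was tested in a functional assay on A549 cells (Homo sapiens) for cytotoxicity, read by MTT assay, with a stated time of 72 h (a lower number here means a stronger inhibitor, a higher number a weaker inhibitor), where compound 3 gives 110 nM. Two related compounds give context. Compound 1 `COc1cc2c(Oc3ccc(NC(=O)c4nnn(-c5ccccc5)c4C)cc3F)ccnc2cc1OCCCN1CCCC1` gives 90 nM in this assay, and compound 2 `COc1cc2c(Oc3ccc(NC(=O)c4nnn(-c5ccc(F)cc5)c4C(F)(F)F)cc3F)ccnc2cc1OCCCN1CCCC1` gives 80 nM. Compound 3 has the highest of the three numbers, but its distance from compound 1 and from compound 2 lies within the scatter, so the three cannot be told apart. For the measured compounds named here, the only step between compounds differing in one place, a 1.4-fold higher number from compound 2 to compound 3 (0.14 log units; within the scatter), also falls within the scatter.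

Compound 4 `COc1cc2c(Oc3ccc(NC(=O)c4nnn(-c5ccc(F)c(F)c5)c4C(F)(F)F)cc3F)ccnc2cc1OCCCN1CCCCC1` is not yet measured. It differs from compound 3 by fluoro in place of hydrogen on an aromatic carbon. Going by the values given here, none of the measured steps concerns adding a fluoro group to this ring; compound 1 and compound 2 differ in two places at once, so their values show only that two changes together left the number within the scatter. Among the compounds with values here, with no measured step bearing on the change, the expected step in this assay is no change at the digits printed from compound 3 to compound 4 (within the scatter), none beyond the scatter. Compound 4 is therefore expected to give 110 nM, with a range from 50 nM to 250 nM.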

Compound 4, half-maximal inhibitory concentration: 160 nM
Compound 4: the middle estimate sits 1.5-fold (0.16 log units) below what was measured; low and high end bracket the measured number.
By their numbers in this assay, from the lowest: compounds 2, 1, 3 and 4 (each within the scatter of the next).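

In this assay, for the compounds shown here, the change from 4-fluorophenyl to 3,4-difluorophenyl gives a 1.5-fold higher number from compound 3 to compound 4 (0.16 log units; within the scatter) and is the first single-place reading of a fluoro group added to this ring. Compound 3 and compound 4 therefore cannot be told apart, and the aromatic carbon ortho to a fluoro group and meta to a large group takes a second fluoro group with no step beyond the scatter. Nothing measured here explains this reading or shows what the added fluorine does at this position.

From the compounds shown here alone, it remains open whether a chloro or methoxy group at the same place would also stay within the scatter. Also open, going by these compounds, is how the 3,4-difluorophenyl ring reads when the chain ends in pyrrolidin-1-yl rather than piperidin-1-yl.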